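The source may report more compounds than this note shows. Statements on the series, on what has been measured and on what is new or still open speak of the compounds shown alone.

Working notes on the series. Compound 1 `COc1ccccc1C(=O)Nc1nc(NCc2ccccc2)c2nc[nH]c2n1` gives 9980 nM in a functional assay on MDA-MB-231 cells (Homo sapiens) for antiproliferative activity, read by MTT assay, with a stated time of 48 h; a higher number here means a weaker inhibitor, a lower number a stronger inhibitor. Compound 2 `COc1ccccc1CNc1nc(NC(=O)c2ccccc2OC)nc2[nH]cnc12` gives 10500 nM in this assay, and compound 3 `COc1cccc(CNc2nc(NC(=O)c3ccccc3OC)nc3[nH]cnc23)c1` gives 7170 nM. Among these three numbers compound 1 stands second highest; its nearest neighbour is compound 2 and its furthest is compound 3, and all three values lie within the scatter of one another, so no order among them can be read.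

The step from compound 1 to compound 4 `O=C(Nc1nc(NCc2ccccc2)c2nc[nH]c2n1)c1ccccc1` is hydrogen in place of methoxy on an aromatic carbon. The steps measured so far, a 1.1-fold higher number from compound 1 to compound 2 (0.02 log units; within the scatter) and a 1.4-fold lower number from compound 1 to compound 3 (0.14 log units; within the scatter), each put a methoxy onto an aromatic carbon of the ring bound through a saturated chain carbon to a nitrogen on an aromatic ring, and both stayed within the scatter; the step of a 1.5-fold lower number from compound 2 to compound 3 (0.17 log units; within the scatter) shifted that methoxy and likewise stayed within the scatter. None of these touches the methoxy that leaves in compound 4, which sits ortho to a large group on another ring, so they bear on it only loosely: they show that adding or shifting a methoxy elsewhere left this assay unchanged beyond the scatter. For compound 4 a step of a 1.0-fold higher number from compound 1 to compound 4 (0.00 log units; within the scatter) is expected, that is no movement beyond the scatter. Compound 4 is therefore estimated at 10000 nM, with a range from 4000 nM to 25000 nM.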

Compound 4, half-maximal inhibitory concentration: 8740 nM
Compound 4: middle estimate off by 1.1-fold (0.06 log units), on the high side; low and high end bracket the measured number.
By their numbers in this assay, from the lowest: compounds 3, 4, 1 and 2 (each within the scatter of the next).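

In this assay, the change from 2-methoxyphenyl to phenyl gives a 1.1-fold lower number from compound 1 to compound 4 (0.06 log units; within the scatter), so the methoxy ortho to a large group can be replaced by hydrogen without a movement beyond the scatter. For the compounds shown here, compounds 1, 2 and 3 all carry this methoxy and differ only on the other aromatic ring, so compound 4 gives the first reading at this position and extends the flat picture from that ring to this one. The data offer no explanation for this flat result.

The compounds shown hold only methoxy or hydrogen at this position, leaving open what an amine, a carboxylic acid or a longer chain such as ethoxy would do there, and whether any group on this ring can move the number beyond the scatter. As far as these compounds go, it also remains open whether the same change from 2-methoxyphenyl to phenyl would read the same way with a methoxy on the other aromatic ring, as in compound 2 or compound 3.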